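The source may report more compounds than this note shows. Statements on the series, on what has been measured and on what is new or still open speak of the compounds shown alone.

Compound 1 `O=C(CCCc1ccc(F)cn1)N1CCc2c(Cl)c(O)c(O)c(Cl)c2C1`: 89%
Compound 2 `O=C(CCCc1ccc(C(F)(F)F)cn1)N1CCc2c(Cl)c(O)c(O)c(Cl)c2C1`: 72%
Compound 3 `COc1ccc(CCCC(=O)N2CCc3c(Cl)c(O)c(O)c(Cl)c3C2)nc1`: 96%

The three share one core and differ only in the group on the aromatic ring with 1 nitrogen. In a functional assay (Homo sapiens), tested at 1 uM (a higher number here means a weaker effect of the compound at the concentration tested, a lower number a stronger effect), compound 2 stands lowest of the three: compound 1 lies higher, a number 17 percentage points lower from compound 1 to compound 2 (beyond the scatter) read backwards, and compound 3 higher still, a number 24 percentage points higher from compound 2 to compound 3 (beyond the scatter); compound 1 and compound 3 sit within the scatter of each other, a number 7 percentage points higher from compound 1 to compound 3 (within the scatter).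

Compound 4 `O=C(CCCc1ncc(C(F)(F)F)cc1-c1ccccc1)N1CCc2c(Cl)c(O)c(O)c(Cl)c2C1` differs from compound 2 by phenyl in place of hydrogen on an aromatic carbon. Among the measured compounds shown here, no measured step bears on this change: the three steps exchange small groups on another carbon, none adds a phenyl. There is thus no basis for a direction, and a wide range is warranted. Compound 4 is expected to give 70%, between 45% and 95%. That expectation amounts to a step of a number 2 percentage points lower from compound 2 to compound 4 (within the scatter).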

Compound 4, a percentage reported as activity, at one concentration (the size of the read-out at that concentration, not a potency): 90%
Beside the measured number, compound 4's estimate is 20 percentage points below it, within the range that was stated.
By their numbers in this assay, from the lowest: compound 2; then compounds 1, 4 and 3 (each within the scatter of the next).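

In this assay the phenyl on this aromatic carbon, ortho to a large group and meta to a trifluoromethyl group, is not a neutral addition: a number 18 percentage points higher from compound 2 to compound 4 (beyond the scatter) and so a weaker effect at the concentration tested. Among the compounds shown, only compound 4 carries a group other than hydrogen on this carbon. No data on hand account for this step.

Open, as far as these compounds go, is whether a methyl group or an amine on this same carbon would follow compound 2 or compound 4. Also open, from the compounds shown here alone, is whether phenyl here gives a similar step with fluoro or methoxy in place of trifluoromethyl.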